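Swapping a Pyridine for a Tolyl Group on the Core

The compounds below may be only part of what the source reports. "The series", "measured", "known", "first", "only" and "open" are said of these compounds alone.

Three close relatives of one shared core are compared here. Compound 1 `CCCCCc1ccc(Nc2ccc3c(c2)C(=O)N(C2CCC(=O)NC2=O)C3=O)cc1` carries a 4-pentylphenylamino group on the core; in an assay on FRT-Jurkat cells for inhibition of nuclear factor NF-kappa-B complex (Homo sapiens), read by flow cytometry, with a stated time of 24 h, tested at 10 uM (a higher number here means more inhibition at the concentration tested (going by the name of the read-out), a lower number less inhibition), compound 1 gives 12%. Compound 2 `O=C1CCC(N2C(=O)c3cccc(Nc4ccccn4)c3C2=O)C(=O)N1` carries a pyridin-2-ylamino group instead; in this assay compound 2 gives 1%, the lower of the two numbers, and the gap to compound 1 lies beyond the usual scatter of such measurements. Compound 3 `Cc1ccc(Nc2cccc3c2C(=O)N(C2CCC(=O)NC2=O)C3=O)cc1` has not yet been measured. It is built like compound 2, with one change: 4-methylphenyl in place of pyridin-2-yl on a nitrogen on an aromatic ring. Within the data shown here, no measured pair isolates exactly this change, so the expectation rests on the two values shown. Since compound 1, with its aryl amino group, gives 12% while compound 2 gives 1%, a modest rise is expected for compound 3, though one that may well stay within the scatter. The step from compound 2 to compound 3 is estimated at a number 7 percentage points higher from compound 2 to compound 3 (within the scatter). Compound 3 is expected to give about 8% in this assay, with a likely range from 0% to 20%.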

Compound 3, a percentage reported as inhibition, at one concentration (the size of the read-out at that concentration, not a potency): 9%
Estimate against measurement, compound 3: 1 percentage points below; the range from low to high includes it.
By their numbers in this assay, from the lowest: compounds 2, 3 and 1 (each within the scatter of the next, the first and the last beyond it).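

The swap of pyridin-2-yl for 4-methylphenyl on a nitrogen on an aromatic ring now has a direct reading in this assay, which comes to a number 8 percentage points higher from compound 2 to compound 3 (within the scatter). An all-carbon ring bearing a methyl group can therefore stand in place of a ring with a hetero atom at this position without the two compounds being told apart in this single-concentration read-out, something the earlier comparison of compound 1 and compound 2 could not show, since those two compounds differ in more than one place. Nothing available explains why compound 2 and compound 3 read alike.

The swap also bundles two differences, the loss of the ring nitrogen and the gain of the methyl group, and a plain phenyl group on the same nitrogen would be needed to pull them apart. As far as these compounds go, it also remains open whether a carboxylic acid, an amine or a longer chain such as pentyl in place of that methyl group would move the reading beyond the usual scatter on this core.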